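Amino substitution on the core of compound 2

The source may hold more compounds than are shown below. What is called first, only, known or untested is meant among the compounds shown, and "the series" means these compounds.

Compound 1 `ClCc1ccccc1Cn1cnc2c(Cl)nc(Cl)nc21` and compound 2 `ClCc1ccccc1Cn1cnc2c(Cl)ncnc21` differ only in the chloro on the core. In a functional assay on OVCAR-5 cells (Homo sapiens) for cytotoxicity, read by sulforhodamine B assay, with a stated time of 48 h (on this read-out higher numbers stand for weaker inhibition of growth and lower numbers for stronger inhibition of growth), compound 1 gives 1580 nM and compound 2 gives 2450 nM; the step is a 1.6-fold higher number from compound 1 to compound 2 (0.19 log units; within the scatter). Compound 3 `ClCc1cccc(Cn2cnc3c(Cl)ncnc32)c1` gives 2080 nM. Compound 2 therefore holds the highest of the three numbers, although all three lie within the scatter of one another. Compound 4 `Nc1nc(Cl)c2ncn(Cc3ccccc3CCl)c2n1` carries amino in place of hydrogen on an aromatic carbon. Going by the values given here, no measured pair exchanges hydrogen for amino; the only step at that carbon, a 1.6-fold higher number from compound 1 to compound 2 (0.19 log units; within the scatter), stayed within the scatter, so no change beyond the scatter is expected for the step of a 1.1-fold lower number from compound 2 to compound 4 (0.05 log units; within the scatter). Compound 4 is thus expected at 2200 nM, with a range from 700 nM to 7000 nM.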

Compound 4, concentration for 50% growth inhibition: 20000 nM
Beside the measured number, compound 4's estimate is 9.1-fold (0.96 log units) below it, outside the stated range (above it).
By their numbers in this assay, from the lowest: compounds 1, 3 and 2 (each within the scatter of the next); then compound 4.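

At the aromatic carbon between two ring nitrogen atoms, the earlier exchange of chloro for hydrogen stayed within the scatter, whereas amino moves the number beyond it in this assay (this assay), with both steps pointing to weaker inhibition of growth (an 8.2-fold higher number from compound 2 to compound 4 (0.91 log units; beyond the scatter); a 13-fold higher number from compound 1 to compound 4 (1.10 log units; beyond the scatter)). This carbon is therefore not indifferent to its substituent, at least for amino. No measurement here bears on the cause of this step. As far as these compounds go, whether a methylamino, dimethylamino or methoxy group at this carbon would follow amino remains open.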